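The compounds below may be only part of what the source reports. "The series", "measured", "known", "first", "only" and "open" are said of these compounds alone.

Compound 1 `CC1(C)CC(=O)C2=C(C1)N(c1ccccc1)N=C(c1ccccc1)C2` stands second highest of the three compounds measured in a functional assay on the whole organism (strain CF) for inhibition, with Mus musculus as the target, at a dose of 25 mg/kg by the oral route (on this read-out higher numbers stand for more inhibition at the one dose given (going by the name of the read-out) and lower numbers for less inhibition), where compound 1 gives 26%. Its nearest neighbour, compound 3 `CC1(C)CC(=O)C(CC(=O)c2ccccc2)=C(NNC(=O)c2ccncc2)C1`, gives 51%, a gap beyond the scatter. Compound 2 `CC1=NNC2=C(C1)C(=O)CC(C)(C)C2`, which carries no phenyl, gives 0%, a gap in the other direction that is also beyond the scatter. Compound 4 `CN1N=C(c2ccccc2)CC2=C1CC(C)(C)CC2=O` has not yet been measured; it differs from compound 1 in one place: methyl in place of phenyl on an amine nitrogen in a ring. Among the compounds with values here, no measured pair shows this change on its own. Because compound 2 without a phenyl gives 0%, a drop beyond the scatter is expected, and the step is estimated at a number 16 percentage points lower from compound 1 to compound 4 (beyond the scatter) in this assay. For compound 4 the estimate is 10%, ranging from 0% to 30%.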

Compound 4, a percentage reported as inhibition, in the whole organism at one dose (the size of the read-out at that dose, not a potency): 51%
The estimate for compound 4 lay 41 percentage points below the measured number; measured number above the stated range.
By their numbers in this assay, from the lowest: compound 2; then compound 1; then compounds 3 and 4 (each within the scatter of the next).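

In this assay, methyl in place of phenyl on an amine nitrogen in a ring gives a number 25 percentage points higher from compound 1 to compound 4 (beyond the scatter). This single change shows that inhibition at this dose does not depend on a phenyl at this position, and that here the phenyl goes with the lower number. Nothing available explains why the number rises. Going by these compounds, it remains open whether an ethyl group, a longer chain or a benzyl group at this nitrogen would keep or extend the step. The single dose also leaves potency unknown.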